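The source may hold more compounds than are shown below. What is called first, only, known or untested is meant among the compounds shown, and "the series" means these compounds.

Compound 1 `Cc1cc(C)c(CN2CCc3c(Cl)cc([C@@H](CO)[C@@H]4CCOC4)c(Cl)c3C2=O)c(=O)[nH]1` stands second highest of the three numbers in a physicochemical assay for solubility, measured as kinetic solubility (a higher number here means a more soluble compound, a lower number a less soluble compound), where compound 1 gives 537000 nM. Compound 2 `COc1cc(C)[nH]c(=O)c1CN1CCc2c(Cl)cc([C@@H](O)C3COC3)c(Cl)c2C1=O` gives 582000 nM in this assay, a difference within the scatter, while compound 3 `COc1cc(C)[nH]c(=O)c1CN1CCc2c(Cl)cc([C@H](O)C3COC3)c(Cl)c2C1=O` gives 234000 nM, the lowest of the three. For the measured compounds named here, the only step between measured compounds that differ in one place is a 2.5-fold lower number from compound 2 to compound 3 (0.40 log units; beyond the scatter), and that step rests on (the fact that compounds 2 and 3 differ only in the configuration as drawn). Compound 4 `Cc1cc(C)c(CN2CCc3c(Cl)cc([C@H](CO)[C@@H]4CCCO4)c(Cl)c3C2=O)c(=O)[nH]1` differs from compound 1 by a group of 8 heavy atoms (6 carbon, 2 oxygen; one five-membered non-aromatic ring with 1 hetero atom) in place of a group of 8 heavy atoms (6 carbon, 2 oxygen; one five-membered non-aromatic ring with 1 hetero atom), on an aromatic carbon; the two have the same atoms, joined differently, and the defined stereocentres are drawn differently as well. The measured step bears on this change only loosely, since it covers a change of configuration alone and was modest. A step of at most that size is therefore expected from compound 1 to compound 4, in either direction, and most likely none beyond the scatter, as a 1.2-fold lower number from compound 1 to compound 4 (0.08 log units; within the scatter) describes. Compound 4 is thus estimated to give 450000 nM in this assay, with a range from 180000 nM to 1000000 nM.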

Compound 4, solubility: 400000 nM
Estimate against measurement, compound 4: 1.1-fold (0.05 log units) above; low and high end bracket the measured number.
By their numbers in this assay, from the lowest: compounds 3, 4, 1 and 2 (each within the scatter of the next, the first and the last beyond it).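

The new step in this assay is a 1.3-fold lower number from compound 1 to compound 4 (0.13 log units; within the scatter) and so shows that, at this aromatic carbon ortho to a chloro group, one five-membered non-aromatic ring with 1 hetero atom can replace another of the same atoms, joined differently, with no step beyond the scatter. For the compounds shown here, the only earlier step at this position was a 2.5-fold lower number from compound 2 to compound 3 (0.40 log units; beyond the scatter) and it concerned configuration alone: the fact that compounds 2 and 3 differ only in the configuration as drawn. Compounds 1 and 4 extend the reading to a change of connectivity, although their defined stereocentres are drawn differently as well.

Since connectivity and configuration change together here, neither can be read alone from this pair. On these data alone, how this assay would respond to a group of another kind at this carbon, such as an amine or a carboxylic acid, remains open.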